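A few compounds are considered here, and "the series" means these few. Any claim that something is new, unique, unknown or untested is made for them only; others in the source may bear on it.

Three compounds built on one shared core were tested in a functional assay on Right cardiac atrium for agonist activity at histamine H2 receptor (Cavia porcellus), with a stated time of 30 min, in the presence of a further agent that is not named here; a higher number here means a larger maximal response, a lower number a smaller maximal response. Compound 1 `Cc1nc(N)sc1CCCN/C(N)=N/C(=O)NC(c1ccccc1)C(C)C` reaches 1.04, compound 2 `Cc1nc(N)sc1CCCN/C(N)=N/C(=O)NC(C)c1ccccc1F` reaches 0.93, and compound 3 `Cc1nc(N)sc1CCCN/C(N)=N/C(=S)NC(c1ccccc1)c1ccccc1` reaches 0.67. Compound 2 therefore stands second of the three: compound 1 sits higher by a margin beyond the usual scatter of repeated measurements, and compound 3 sits lower by a wider margin, also beyond that scatter. Among the measured compounds shown here, none of these three differs from another in only one place, so no single step between measured compounds can be read off from them.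

Compound 4 `Cc1nc(N)sc1CCCN/C(N)=N/C(=O)NC(C)c1cccc(F)c1` has not yet been measured in this assay. It differs from compound 2 in one place: 3-fluorophenyl in place of 2-fluorophenyl on a saturated chain carbon bound to an amide-type nitrogen and a saturated chain carbon. For the measured compounds named here, no measured pair shows what the change from 2-fluorophenyl to 3-fluorophenyl does on this core, so the expectation rests on compound 2 alone, without a measured precedent. Compound 4 is expected to give a maximal response close to that of compound 2, and the step a number 0.010 lower from compound 2 to compound 4 (within the scatter) is estimated to stay within the scatter, with no clear direction. The estimate for compound 4 is 0.92, with a range from 0.72 to 1.06.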

Compound 4, intrinsic activity: the largest response reached, as a fraction of the reference agonist's: 0.85
Estimate against measurement, compound 4: 0.070 above; measured number inside the range.
By their numbers in this assay, from the lowest: compound 3; then compounds 4 and 2 (each within the scatter of the next); then compound 1.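

In this assay, the change to 3-fluorophenyl in place of 2-fluorophenyl, on a saturated chain carbon bound to an amide-type nitrogen and a saturated chain carbon, comes to a number 0.080 lower from compound 2 to compound 4 (within the scatter), and this is the only comparison shown on the shared core that isolates a single place. The two groups have the same atoms and the same ring and differ only in how they are joined, so at this position, the maximal response of this pair cannot be told apart from the usual scatter of repeated measurements. Nothing measured here gives a reason for the size of this step.

From the compounds shown here alone, it remains open whether this position would accept groups that differ more from these two, such as a chlorophenyl, a methoxyphenyl or a phenyl ring carrying no fluorine. Also unresolved is what a thiocarbonyl in place of the carbonyl does on its own, since compound 3 differs from every other compound shown in more than that one place.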